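The source may report more compounds than this note shows. Statements on the series, on what has been measured and on what is new or still open speak of the compounds shown alone.

Compound 1 `COc1ccc(Nc2nc(N[C@H]3CC[C@H](N)CC3)nc3c2ncn3CCC(C)C)c(OC)c1`: 7900 nM
Compound 2 `CC(C)CCn1cnc2c(NCc3cccc(Cl)c3)nc(N[C@H]3CC[C@H](N)CC3)nc21`: 6600 nM

These values come from a functional assay on BT-474 cells (Homo sapiens) for inhibition, read by fluorescence, with a stated time of 72 h; on this read-out lower numbers stand for stronger inhibition of growth and higher numbers for weaker inhibition of growth. Among the measured compounds shown here, compound 2 stands at 6600 nM, and the only comparison available is with compound 1, which gives 7900 nM. The two lie within the scatter of each other.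

Compound 3 `COc1cc(Nc2nc(N[C@H]3CC[C@H](N)CC3)nc3c2ncn3CCC(C)C)cc(OC)c1` carries 3,5-dimethoxyphenyl in place of 3-chlorobenzyl on a nitrogen on an aromatic ring. For the measured compounds named here, one measured step bears on this change. It also replaces a dimethoxyphenyl with 3-chlorobenzyl at that nitrogen, though with 2,4-dimethoxyphenyl as the group that leaves: a 1.2-fold lower number from compound 1 to compound 2 (0.08 log units; within the scatter). That step gives no reason to expect a change beyond the scatter in this assay, in either direction, although the data do not test the 3,5-dimethoxyphenyl group itself. The expected step is a 1.1-fold higher number from compound 2 to compound 3 (0.03 log units; within the scatter). For compound 3 the estimated value is 7000 nM, within an expected range of 3000 nM to 16000 nM.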

Compound 3, concentration for 50% growth inhibition: 5900 nM
Compound 3: the middle estimate sits 1.2-fold (0.07 log units) above what was measured; the range from low to high includes it.
By their numbers in this assay, from the lowest: compounds 3, 2 and 1 (each within the scatter of the next).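

In this assay, 3,5-dimethoxyphenyl in place of 3-chlorobenzyl on a nitrogen on an aromatic ring gives a 1.1-fold lower number from compound 2 to compound 3 (0.05 log units; within the scatter), and 3,5-dimethoxyphenyl in place of 2,4-dimethoxyphenyl gives a 1.3-fold lower number from compound 1 to compound 3 (0.13 log units; within the scatter). The second step is new in kind: it alters only where the two methoxy groups stand on the phenyl ring, and this too stays within the scatter, so all three groups at this nitrogen are alike on this read-out. Nothing shown offers an explanation for this sameness.

From the compounds shown here alone, whether a carboxylic acid or a morpholine on the aromatic ring at this nitrogen would bring a step beyond the scatter remains open. So does the effect of a longer chain in place of the 3-methylbutyl group on the shared core, or of a hydroxyl in place of its ring amine.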